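A trifluoromethyl swap in a narrow series

This account rests on a few compounds, and the source may have more. Where it says the series, first, only, none or still open, it means among the compounds named here.

Three close relatives share one core: compound 1 (`COc1ccc(-n2c(-c3cc(OC)c(OC)c(OC)c3)cccc2=O)cc1OCc1ccccc1`), compound 2 (`COc1ccc(-n2c(-c3cc(OC)c(OC)c(OC)c3)cccc2=O)cc1`) and compound 3 (`COc1ccc(-n2c(-c3cc(OC)c(OC)c(OC)c3)cccc2=O)cc1OC`). In a functional assay on HepG2 cells (Homo sapiens) for cytotoxicity, read by spectrophotometry, with a stated time of 72 h (on this read-out higher numbers stand for weaker inhibition and lower numbers for stronger inhibition), their numbers lie close together: compound 1 (3040 nM), compound 2 (5740 nM) and compound 3 (4870 nM). Compound 2 lies within the usual scatter of both others, so these data rank none of the three.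

Compound 4 (`COc1cc(-c2cccc(=O)n2-c2ccc(C(F)(F)F)cc2)cc(OC)c1OC`) has not been measured yet. It differs from compound 2 in one place (trifluoromethyl in place of methoxy on an aromatic carbon): trifluoromethyl in place of methoxy on an aromatic carbon, para to a large group.

Within the data shown here, no measured step makes this exact swap, and no measured compound carries trifluoromethyl, so the evidence is indirect. The two nearest steps are a 1.2-fold lower number from compound 2 to compound 3 (0.07 log units; within the scatter) and a 1.9-fold higher number from compound 1 to compound 2 (0.28 log units; within the scatter) and both stay within the scatter. With only these small steps to go on, the expected step is a 1.1-fold higher number from compound 2 to compound 4 (0.05 log units; within the scatter) in this assay and no shift beyond the scatter is predicted. For compound 4 the estimated value is 6500 nM with an expected range from 2500 nM to 17000 nM as a cautious estimate.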

Compound 4, half-maximal inhibitory concentration: 10200 nM
Compound 4: the middle estimate sits 1.6-fold (0.20 log units) below what was measured, within the range that was stated.
By their numbers in this assay, from the lowest: compounds 1, 3, 2 and 4 (each within the scatter of the next, the first and the last beyond it).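

Among these compounds, all three earlier compounds carry methoxy at this place on the aromatic ring, para to a large group, so compound 4 gives the first reading of a change made there. In this assay, replacing methoxy with trifluoromethyl gives a 1.8-fold higher number from compound 2 to compound 4 (0.25 log units; within the scatter): even with a group of more heavy atoms and no hydrogen-bond acceptor in place of one with an oxygen, the step cannot be told apart from the scatter. Nothing available bears on the reason for this result.

From the compounds shown here alone, it remains open whether an amine, a carboxylic acid or a longer chain such as butoxy at this place would give a step beyond the scatter. The same swap also remains to be read against the benzyloxy or second methoxy carried by compound 1 and compound 3.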